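Phenoxy in Place of Hydrogen on the Four-Membered Ring

The source may report more compounds than this note shows. Statements on the series, on what has been measured and on what is new or still open speak of the compounds shown alone.

Measured compounds:
- compound 1 `CCOc1ccc(C2C(Oc3ccccc3)C(=O)N2c2cc(OC)c(OC)c(OC)c2)cc1`: 388 nM
- compound 2 `CCSc1ccc(C2CC(=O)N2c2cc(OC)c(OC)c(OC)c2)cc1`: 311 nM
- compound 3 `COc1ccc(C2C(C3CC3)C(=O)N2c2cc(OC)c(OC)c(OC)c2)cc1`: 107 nM

In a functional assay on HT-29 cells (Homo sapiens) for inhibition, read by sulforhodamine B assay, with a stated time of 72 h (on this read-out higher numbers stand for weaker inhibition and lower numbers for stronger inhibition), compound 2 gives 311 nM, the second highest of the three numbers. Its nearest neighbour is compound 1, which gives 388 nM in this assay, a gap within the scatter, so the two cannot be ranked. Its furthest neighbour is compound 3, which gives 107 nM, a gap beyond the scatter, so compound 3 inhibits more strongly than compound 2.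

Compound 4 `CCSc1ccc(C2C(Oc3ccccc3)C(=O)N2c2cc(OC)c(OC)c(OC)c2)cc1` has not yet been measured. It differs from compound 2 in one place: phenoxy in place of hydrogen on a saturated ring carbon

Among the measured compounds shown here, no measured pair shows this exact change, so its effect is not yet known. Compound 1 carries a phenoxy group and gives 388 nM, a number within the scatter of compound 2, which gives 311 nM. Hence no step beyond the scatter is expected in this assay; the estimated step of a 1.1-fold higher number from compound 2 to compound 4 (0.05 log units; within the scatter) is small. Compound 4 is expected to give about 350 nM, within 130 nM to 950 nM.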

Compound 4, half-maximal inhibitory concentration: 632 nM
Compound 4: middle estimate off by 1.8-fold (0.26 log units), on the low side, and the stated range covers the measured number.
By their numbers in this assay, from the lowest: compound 3; then compounds 2, 1 and 4 (each within the scatter of the next, the first and the last beyond it).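

Among the compounds shown here, putting phenoxy on this saturated ring carbon of the four-membered ring, in place of hydrogen, weakens inhibition in this assay, with a 2.0-fold higher number from compound 2 to compound 4 (0.31 log units; beyond the scatter), a modest change and the first direct reading of this swap. With phenoxy present, ethylsulfanyl in place of ethoxy on the aromatic carbon gives a 1.6-fold higher number from compound 1 to compound 4 (0.21 log units; within the scatter), so the two groups cannot be told apart on this pair. Nothing measured here accounts for the phenoxy step.

As far as these compounds go, whether phenoxy has the same effect when ethoxy rather than ethylsulfanyl sits on the aromatic ring remains open. From the compounds shown here alone, it is also open how this ring carbon would respond to a much smaller oxygen group such as hydroxyl, or to an amine.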